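The source may report more compounds than this note shows. Statements on the series, on what has been measured and on what is new or still open speak of the compounds shown alone.

In a functional assay on DWD cells (Homo sapiens) for inhibition, read by sulforhodamine B assay (on this read-out lower numbers stand for stronger inhibition of growth and higher numbers for weaker inhibition of growth), compound 1 `c1ccc(-c2ccc(-c3ccc(-c4nc5ccccc5[nH]4)cc3)cc2)cc1` gives 100000 nM, while compound 2 `Cc1ccc2[nH]c(-c3ccc(-c4ccc(-c5ccc(N(C)C)cc5)cc4)cc3)nc2c1` gives 3230 nM. Compound 2 therefore holds the lower of the two numbers, and the gap lies beyond the scatter, so it is the stronger growth inhibitor of this pair. The next compound to test, compound 3 `Cc1ccc2[nH]c(-c3ccc(-c4ccc(-c5cccc(Cl)c5)cc4)cc3)nc2c1`, keeps most of compound 2 and changes one end of the molecule: it has 3-chlorophenyl in place of 4-(dimethylamino)phenyl on an aromatic carbon. For the measured compounds named here, no measured pair isolates this change, so any forecast is uncertain. Going by the values given here, the only hint comes from compound 1, at 100000 nM, which also has no 4-(dimethylamino)phenyl group and sits higher in this assay. It differs from compound 2 in more than one place, however, so it is a weak guide. A moderate loss of growth inhibition therefore seems likely, with an expected step of a 2.5-fold higher number from compound 2 to compound 3 (0.39 log units; beyond the scatter) that is only a little beyond the scatter. For compound 3 the estimated value is 8000 nM, with a range from 2000 nM to 40000 nM.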

Compound 3, concentration for 50% growth inhibition: 2510 nM
Compound 3: middle estimate off by 3.2-fold (0.50 log units), on the high side; the range from low to high includes it.
By their numbers in this assay, from the lowest: compounds 3 and 2 (each within the scatter of the next); then compound 1.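

In this assay, putting 3-chlorophenyl in place of 4-(dimethylamino)phenyl gives a 1.3-fold lower number from compound 2 to compound 3 (0.11 log units; within the scatter) and so leaves growth inhibition level with that of compound 2. For the compounds shown here, this is the first comparison that isolates this end of the molecule, and it shows that, at this aromatic carbon, the 4-(dimethylamino)phenyl group can give way to a group with a chlorine instead of a nitrogen, 7 heavy atoms instead of 9, and no hydrogen-bond acceptor instead of 1, with no measurable cost in this assay. Nothing available here explains why these two groups give matching results.

Still open, on these data alone, is whether the same level would hold with a different kind of group at this place, such as a carboxylic acid, a morpholine or a longer chain ending in an amine. The much weaker result for compound 1 also remains unexplained, as it differs from compound 2 and compound 3 in more than one place, so no single change can be linked to that gap.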